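Lengthening a Methyl to Propyl on the Phenyl Ring

A few compounds are considered here, and "the series" means these few. Any claim that something is new, unique, unknown or untested is made for them only; others in the source may bear on it.

Compound 1, `CN(C)C(=O)c1cccnc1NCCCN1CCN(c2ccccc2-c2ncco2)CC1`, gives 25.1 nM.
Compound 2, `Cc1ccccc1N1CCN(CCCNc2ncccc2C(=O)N(C)C)CC1`, gives 10 nM.

Both numbers come from a functional assay on aorta for antagonist activity at Alpha-1D adrenergic receptor (Rattus norvegicus); on this read-out lower numbers stand for tighter binding and higher numbers for weaker binding. Among the measured compounds shown here, compound 2 stands at the lower of the two numbers; the single step between them, a 2.5-fold lower number from compound 1 to compound 2 (0.40 log units; beyond the scatter), is a modest move beyond the scatter, and it concerns a different change, methyl in place of 1,3-oxazol-2-yl on an aromatic carbon. Compound 3, `CCCc1ccccc1N1CCN(CCCNc2ncccc2C(=O)N(C)C)CC1`, has not yet been measured. It differs from compound 2 by ethyl in place of hydrogen on a saturated chain carbon bound to an aromatic carbon; cut one bond further out, the change reads methyl to propyl, or 2-methylphenyl to 2-propylphenyl. No measured step touches this chain: the only step shown replaces a whole ring with a methyl group rather than lengthening a methyl group. With nothing to lean on beyond compound 2 itself, the expectation is a step of no change at the digits printed from compound 2 to compound 3 (within the scatter), which amounts to no change beyond the scatter in this assay. Compound 3 is therefore estimated at 10 nM, with a likely range from 3 nM to 32 nM.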

Compound 3, dissociation constant: 31.6 nM
The estimate for compound 3 lay 3.2-fold (0.50 log units) below the measured number; the measured number falls inside the stated range.
By their numbers in this assay, from the lowest: compound 2; then compounds 1 and 3 (each within the scatter of the next).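

In this assay, the group on the phenyl ring proves sensitive to chain length: going from 2-methylphenyl to 2-propylphenyl gives a 3.2-fold higher number from compound 2 to compound 3 (0.50 log units; beyond the scatter) so the longer chain costs a modest but real amount. Putting propyl in place of 1,3-oxazol-2-yl gives a 1.3-fold higher number from compound 1 to compound 3 (0.10 log units; within the scatter) so a chain and a ring cannot be told apart here, and of the three groups shown, only methyl stands clear of the other two. Nothing available here offers an explanation for the rise seen with the longer chain.

The compounds shown leave open whether the number climbs steadily with chain length, as 2-ethylphenyl would show, or whether a longer chain such as butyl would push it higher still. They also leave open how a branched group such as isopropyl, or a group carrying oxygen such as methoxy, would compare with methyl and propyl at this same place on the shared core.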